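The source may hold more compounds than are shown below. What is called first, only, known or untested is meant among the compounds shown, and "the series" means these compounds.

Measured compounds:
compound 1, `CC(C)N(Cc1cccc(OCCCCCC(=O)O)c1)C(=O)c1ccc(-c2ccoc2)cc1`: > 26000 nM
compound 2, `CC(C)Oc1cccc(-c2ccc(C(=O)N(Cc3cccc(OCCCCCC(=O)O)c3)C(C)C)cc2)c1`: > 26000 nM
compound 3, `CCOC(=O)CCCCCOc1cccc(CN(C(=O)c2ccc(-c3ccoc3)cc2)C(C)C)c1`: > 26000 nM

These three compounds were tested in an ADME assay on HEK293 cells (Homo sapiens) for cytotoxicity, read by CellTiter-Glo and resazurin assay, with a stated time of 72 h; on this read-out lower numbers stand for an effect already at smaller amounts and higher numbers for an effect only at larger amounts of compound. Compound 1 reaches only the limit of this assay, > 26000 nM, which is a limit and not a number. Compound 2 likewise stands at a limit, > 26000 nM. Compound 3 also gives only a limit, > 26000 nM.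

The change from compound 1 to compound 2 is 3-isopropoxyphenyl in place of furan-3-yl on an aromatic carbon, and the step it made is a step that the two limits leave unreadable from compound 1 to compound 2; the two limits leave its size unreadable, because of the limit of > 26000 nM in this assay, at which 3 of the 3 values shown sit.

Compound 1 and compound 3 differ in their cores by ethyl in place of hydrogen on an oxygen next to a carbonyl group, with the step that the two limits leave unreadable from compound 1 to compound 3, again unreadable from the two limits.

Compound 4, `CCOC(=O)CCCCCOc1cccc(CN(C(=O)c2ccc(-c3cccc(OC(C)C)c3)cc2)C(C)C)c1`, has not been measured in this assay. It differs from compound 3 by 3-isopropoxyphenyl in place of furan-3-yl on an aromatic carbon, the same change as that from compound 1 to compound 2. Since that earlier step stayed unreadable between two limits, the step from compound 3 to compound 4 is expected to be a step that the limit leaves unreadable from compound 3 to compound 4, resting on the limit of compound 3, > 26000 nM. Compound 4 is therefore estimated at 40000 nM, between 15000 nM and 150000 nM, most likely reported as a limit.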

Compound 4, half-maximal effective concentration: > 26000 nM
Compound 4: no number, only a limit; the forecaster's own chance of this, stated with the estimate: 80%; the middle value does not contradict the limit.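

In this assay compound 4 gives > 26000 nM, which is a limit and not a number. No new step can be read from compound 4 to compound 2 or compound 3, because all of these values sit at one limit: the limit of > 26000 nM in this assay, at which 4 of the 4 values shown sit.

The compounds shown leave open at what concentration any of them would show an effect in this assay, and whether either change alters that concentration.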